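A Furan Replaces a Thiophene on the Enone Arm

The source may hold more compounds than are shown below. What is called first, only, known or untested is meant among the compounds shown, and "the series" means these compounds.

Compound 3 `COc1ccc(C(=O)/C=C/c2ccsc2)c2c1C=CC(C)(C)O2` belongs to a small family of three measured compounds that share one core. In a functional assay on HCT-116 cells (Homo sapiens) for antiproliferative activity, read by MTT assay, with a stated time of 24 h (a lower number here means a stronger inhibitor, a higher number a weaker inhibitor), compound 1 `COc1ccc(C(=O)/C=C/c2ccc([N+](=O)[O-])cc2)c2c1C=CC(C)(C)O2` gives 8880 nM. Compound 2 `COc1ccc(C(=O)/C=C/c2ccccc2)c2c1C=CC(C)(C)O2` reaches only the limit of this assay, > 10000 nM. Compound 3 likewise sits at the limit of this assay, giving > 10000 nM. So compound 3 stands at the weak end of the shown numbers, where a limit rather than a figure is reported, as described by the limit of > 10000 nM in this assay, at which 2 of the 3 values shown sit.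

Compound 4 `COc1ccc(C(=O)/C=C/c2ccco2)c2c1C=CC(C)(C)O2` differs from compound 3 in one place: furan-2-yl in place of thiophen-3-yl on a double-bonded chain carbon bound to a double-bonded chain carbon. The measured steps that touch the same place are the swap from the 4-nitrophenyl group, an at least 1.1-fold higher number from compound 1 to compound 3 (0.05 log units; that floor lies within the scatter), and the swap from the phenyl group, a step that the two limits leave unreadable from compound 2 to compound 3. Neither shows a readable gain. Going by the values given here, no measured step compares a furan with a thiophene. Compound 4 is expected to stay near that limit, so a step that the limit leaves unreadable from compound 3 to compound 4 is the estimated step. Compound 4 is therefore estimated at 12000 nM, within 5000 nM to 30000 nM, with a fair chance that this assay again reports only a limit.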

Compound 4, half-maximal inhibitory concentration: > 10000 nM
Compound 4: no number, only a limit (the forecaster's own chance of this, stated with the estimate: 65%); the middle value is on the limit's open side.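

Compound 4 brings a furan-2-yl group to this position, and it gives no number any more than the thiophen-3-yl and phenyl groups do, so three different rings without a nitro group now end at the same limit: the limit of > 10000 nM in this assay, at which 3 of the 4 values shown sit.

Going by these compounds alone, the only readable comparison with compound 4 in this assay is an at least 1.1-fold higher number from compound 1 to compound 4 (0.05 log units; that floor lies within the scatter), so even the 4-nitrophenyl group cannot be said to do better than the furan. The steps that join two limits cannot be read, which means the furan-2-yl, thiophen-3-yl and phenyl groups cannot be put in any order.

The compounds shown leave open whether a 4-aminophenyl group would give a number here, as the 4-nitrophenyl group does. They also leave open how a thiophen-2-yl group would compare with the furan-2-yl group at this position.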